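The source may report more compounds than this note shows. Statements on the series, on what has been measured and on what is new or still open speak of the compounds shown alone.

Of the compounds shown here, three of a shared core have been tested in a toxicity assay on HeLa cells (Homo sapiens) for cytotoxicity, read by colorimetric assay, with a stated time of 72 h; on this read-out higher numbers stand for lower toxicity in this test and lower numbers for higher toxicity in this test. Compound 1 `O=c1nc(N2CCC(CCO)CC2)sc2c([N+](=O)[O-])cc(C(F)(F)F)cc12` gives 91500 nM. Compound 2 `O=c1nc(N2CCC(Oc3ccc(OC(F)(F)F)cc3)CC2)sc2c([N+](=O)[O-])cc(C(F)(F)F)cc12` reaches only a limit of the assay, reported as > 93000 nM. Compound 3 `CN(CCCCCCO)c1nc(=O)c2cc(C(F)(F)F)cc([N+](=O)[O-])c2s1` gives 101000 nM, which is the highest of the two numbers read out, with compound 1 nearest to it. The remaining value, that of compound 2, is a limit, as noted in the limit of > 93000 nM in this assay, at which 1 of the 3 values shown sits. The two measured steps are small: an at least 1.0-fold higher number from compound 1 to compound 2 (0.00 log units; that floor lies within the scatter) and a 1.1-fold higher number from compound 1 to compound 3 (0.04 log units; within the scatter).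

Compound 4 `CCCCCCN(C)c1nc(=O)c2cc(C(F)(F)F)cc([N+](=O)[O-])c2s1` has not yet been measured in this assay. It differs from compound 3 by hydrogen in place of hydroxy on a saturated chain carbon, six bonds along the chain from a nitrogen on an aromatic ring. Neither measured step touches this hydroxy, and both of them lie within the scatter, so nothing in the numbers points to a change in either direction. Compound 4 is therefore expected to show a 1.1-fold lower number from compound 3 to compound 4 (0.05 log units; within the scatter), that is no step beyond the scatter. The estimate for compound 4 in this assay is 90000 nM, with a range from 45000 nM to 180000 nM.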

Compound 4, half-maximal cytotoxic concentration: 75500 nM
Compound 4: the middle estimate sits 1.2-fold (0.08 log units) above what was measured; measured number inside the range.
By their numbers in this assay, from the lowest: compounds 4, 1 and 3 (each within the scatter of the next).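

Hydrogen in place of hydroxy on a saturated chain carbon, six bonds along the chain from a nitrogen on an aromatic ring, gives a 1.3-fold lower number from compound 3 to compound 4 (0.13 log units; within the scatter) in this assay, so losing this hydroxy leaves no readable mark on the number. Hexyl(methyl)amino in place of 4-(2-hydroxyethyl)piperidin-1-yl likewise gives a 1.2-fold lower number from compound 1 to compound 4 (0.08 log units; within the scatter) here, so a chain with no hydroxy stands level with both hydroxy-bearing compounds. No measured property shown here bears on this result.

Going by these compounds, it remains open whether an amine, a carboxylic acid or a longer chain at this position would move the number beyond the scatter. On these data alone, it also remains open whether hydrogen in place of the hydroxy of the 2-hydroxyethyl group in compound 1 would behave the same way.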